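Fluoro Next to the Ring Nitrogen

The compounds below may be only part of what the source reports. "The series", "measured", "known", "first", "only" and "open" are said of these compounds alone.

Three compounds were examined as inhibitors of prostate cancer cell growth. Compound 1 `CCN(c1cccc(-c2ccccc2)c1)c1ccc(C#N)c(Cl)c1` has no reported result: in a functional assay on VCaP cells (Homo sapiens) for antiproliferative activity, read by CCK-8 assay, with a stated time of 6 days (a higher number here means a weaker inhibitor, a lower number a stronger inhibitor), compound 1 gives "not determined" (no result reported). Going by the values given here, compound 2 `CCN(c1ccc(C#N)c(Cl)c1)c1cc(-c2cccnc2)ccc1C` is the only one with a plain number: in this assay compound 2 gives 1270 nM. Compound 3 `N#Cc1ccc(N2CCCc3c(-c4ccncc4)cccc32)cc1C(F)(F)F` reaches only a limit of this assay: in this assay compound 3 gives > 30000 nM, which is a limit and not a number, as shown by the limit of > 30000 nM in this assay, at which 1 of the 3 values shown sits. Among the compounds with values here, no two of the measured compounds differ in a single place, so no measured step exists to guide expectations. Compound 4 `CCN(c1ccc(C#N)c(Cl)c1)c1cc(-c2ccc(F)nc2)ccc1C` differs from compound 2 by fluoro in place of hydrogen on an aromatic carbon, the fluoro entering next to the ring nitrogen and turning pyridin-3-yl into 6-fluoropyridin-3-yl. Within the data shown here, with no measured step to lean on, the expected step from compound 2 to compound 4 is a 1.1-fold lower number from compound 2 to compound 4 (0.02 log units; within the scatter), no larger than the usual scatter in this assay. Compound 4 is therefore expected at 1200 nM, with a range from 400 nM to 4000 nM.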

Compound 4, half-maximal inhibitory concentration: > 30000 nM
Compound 4: only a limit was reported (the forecaster's own chance of this, stated with the estimate: 5%); middle value at least 25-fold (1.39 log units) away from the limit.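

In this assay, a single fluoro next to the ring nitrogen, turning pyridin-3-yl into 6-fluoropyridin-3-yl, gives an at least 23-fold higher number from compound 2 to compound 4 (1.37 log units; beyond the scatter). Going by these compounds alone, this is the first measured one-place change, and it shows that this position is highly sensitive: adding 1 heavy atom here takes a compound with a plain number to one without. The result for compound 4 is a limit and not a number, and the true size of the step stays unknown: the limit of > 30000 nM in this assay, at which 2 of the 4 values shown sit.

From the compounds shown here alone, what remains open is whether the loss is specific to fluoro or would follow any replacement of hydrogen at this position. A methoxy group or an amine in the same place, or fluoro on another carbon of this ring, would help separate those possibilities.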